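A Trifluoromethyl Variant in a Small Cell Growth Series

A few compounds are considered here, and "the series" means these few. Any claim that something is new, unique, unknown or untested is made for them only; others in the source may bear on it.

Of the compounds shown here, three sharing one core have been tested in a functional assay on SNB-19 cells (Homo sapiens) for inhibition, read by sulforhodamine B assay, with a stated time of 48 h, tested at 10 uM; a higher number here means more inhibition at the concentration tested (going by the name of the read-out), a lower number less inhibition. Compound 1 `Brc1ccc(-c2cn3ccnc3c(-c3ccc4ncn(C5CCCCC5)c4c3)n2)cc1` gives 18.3%. Compound 2 `COc1ccccc1-c1cn2ccnc2c(-c2ccc3ncn(C4CCCCC4)c3c2)n1` gives 11.1%, and compound 3 `Fc1ccccc1-c1cn2ccnc2c(-c2ccc3ncn(C4CCCCC4)c3c2)n1` gives 7.56%. On these numbers compound 3 stands at the low end: its gap to compound 2 lies within the scatter, while its gap to compound 1 lies beyond it, so only compound 1 is clearly separated from it.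

The next compound is compound 4 `FC(F)(F)c1cccc(-c2cn3ccnc3c(-c3ccc4ncn(C5CCCCC5)c4c3)n2)c1`, which differs from compound 3 in one place: 3-(trifluoromethyl)phenyl in place of 2-fluorophenyl on an aromatic carbon.

The steps already measured all swap one phenyl group for another on the same aromatic carbon. The step of a number 10.7 percentage points lower from compound 1 to compound 3 (beyond the scatter) is the only one beyond the scatter and is modest; the steps of a number 7.2 percentage points lower from compound 1 to compound 2 (within the scatter) and a number 3.5 percentage points lower from compound 2 to compound 3 (within the scatter) are within it. Three different phenyl groups thus give numbers spanning only a modest range in this assay. A fourth phenyl group is therefore expected to land in the same low region, with no step beyond the scatter expected for a number 4.4 percentage points higher from compound 3 to compound 4 (within the scatter).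

Compound 4 is estimated to give 12% in this assay, with a plausible range from 0% to 28%.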

Compound 4, a percentage reported as inhibition, at one concentration (the size of the read-out at that concentration, not a potency): 2.24%
Compound 4: the middle estimate sits 9.8 percentage points above what was measured; the measured number falls inside the stated range.
By their numbers in this assay, from the lowest: compounds 4, 3, 2 and 1 (each within the scatter of the next, the first and the last beyond it).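

At this aromatic carbon of the shared core, 3-(trifluoromethyl)phenyl stays in the same low region as the two ortho-free labels would suggest

Correction of the passage follows in full:

At this aromatic carbon of the shared core, 3-(trifluoromethyl)phenyl adds to the picture in this assay: its step from 2-fluorophenyl is a number 5.3 percentage points lower from compound 3 to compound 4 (within the scatter), and its step from 2-methoxyphenyl is a number 8.9 percentage points lower from compound 2 to compound 4 (within the scatter), so neither change separates it from those groups. Within the data shown here, only the comparison with 4-bromophenyl gives a clear difference, a number 16.1 percentage points lower from compound 1 to compound 4 (beyond the scatter), which makes compound 1 the one compound here that stands apart from both compound 3 and compound 4, though not from compound 2. Nothing available explains these differences.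

The compounds shown cannot tell whether that difference belongs to the bromine itself or to where it sits on the phenyl ring, since the substituent and its ring position change together in these comparisons. They also leave open whether a group other than a substituted phenyl at this carbon, such as a simple amine or a carboxylic acid, would move the number out of this low region.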